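Inverting the chain stereocentre of compound 2

The source may hold more compounds than are shown below. What is called first, only, known or untested is meant among the compounds shown, and "the series" means these compounds.

Compound 1 `CCCCCCCCCCCCCCCCCCOCC(COP(=O)(O)O[C@@H](C)C[N+](C)(C)C)OC` and compound 2 `CCCCCCCCCCCCCCCCCCOCC(COP(=O)(O)OC[C@@H](C)[N+](C)(C)C)OC` differ only in the group on the oxygen; in a functional assay on CCRF-CEM cells (Homo sapiens) for cytotoxicity, with a stated time of 24 h (a higher number here means a weaker inhibitor, a lower number a stronger inhibitor), compound 1 gives 2.3 ug/mL and compound 2 gives 2 ug/mL, a step of a 1.2-fold lower number from compound 1 to compound 2 (0.06 log units; within the scatter). Compound 2 holds the lowest of the two numbers, with compound 1 within the scatter of it. Compound 3 `CCCCCCCCCCCCCCCCCCOCC(COP(=O)(O)OC[C@H](C)[N+](C)(C)C)OC` differs from compound 2 as follows: the two compounds have the same atoms and bonds; at least one stereo element is drawn with a configuration in one of them and without one in the other: 1 of 3 stereo elements differ; a stereocentre at a saturated chain carbon is drawn R in compound 2 and S in compound 3. Within the data shown here, no measured step bears on such an inversion, and the single measured step lies within the scatter. The expectation for compound 3 is accordingly no step beyond the scatter, a 1.1-fold higher number from compound 2 to compound 3 (0.04 log units; within the scatter). Compound 3 is estimated at 2.2 ug/mL, with a range from 1 ug/mL to 4.8 ug/mL.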

Compound 3, concentration for 50% inhibition: 2.1 ug/mL
Estimate against measurement, compound 3: 1.0-fold (0.02 log units) above; the measured number falls inside the stated range.
By their numbers in this assay, from the lowest: compounds 2, 3 and 1 (each within the scatter of the next).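

In this assay, inverting the saturated chain carbon from R to S gives a 1.1-fold higher number from compound 2 to compound 3 (0.02 log units; within the scatter), so configuration at this stereocentre does not separate the pair. Among these compounds, exchanging the group of 7 heavy atoms on the oxygen, earlier seen only with compound 2, gives a 1.1-fold lower number from compound 1 to compound 3 (0.04 log units; within the scatter) and likewise separates nothing. The inversion is read with one reservation: the fact that one of compounds 2 and 3 is drawn with a defined configuration and the other without, at the place where they differ.

On these data alone, whether inverting the stereocentre of compound 1 would behave alike stays open. So does the effect of a primary amine in place of the trimethylammonium group.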